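Replacing the diol amide of compound 3 with a methylpiperidine

The compounds below may be only part of what the source reports. "The series", "measured", "known", "first", "only" and "open" are said of these compounds alone.

Of the compounds shown here, three sharing one core have been measured in a functional assay on HCT-116 cells (Homo sapiens) for antiproliferative activity, read by MTT assay, with a stated time of 48 h; on this read-out higher numbers stand for weaker inhibition and lower numbers for stronger inhibition. Compound 1 (`Cc1c(C(=O)NCCCN(C)C)oc2ccc(N(Cc3ccc(Br)cc3)S(=O)(=O)c3ccc(Br)cc3)cc12`) gives 3070 nM, compound 2 (`Cc1c(C(=O)OCCCN(C)C)oc2ccc(N(Cc3ccc(Br)cc3)S(=O)(=O)c3ccc(Br)cc3)cc12`) gives 11200 nM, and compound 3 (`Cc1c(C(=O)NCC(O)CO)oc2ccc(N(Cc3ccc(Br)cc3)S(=O)(=O)c3ccc(Br)cc3)cc12`) gives 27800 nM. Compound 3 therefore has the highest number of the three and is the weakest inhibitor. The next change leads to compound 4 (`Cc1c(C(=O)N2CCCC(C)C2)oc2ccc(N(Cc3ccc(Br)cc3)S(=O)(=O)c3ccc(Br)cc3)cc12`), with 3-methylpiperidin-1-yl in place of (2,3-dihydroxypropyl)amino on a carbonyl carbon.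

Going by the values given here, all the measured steps change the group on this carbonyl carbon. The two that end at compound 3 are modest but beyond the scatter: a 9.1-fold higher number from compound 1 to compound 3 (0.96 log units; beyond the scatter) and a 2.5-fold higher number from compound 2 to compound 3 (0.39 log units; beyond the scatter). Both start from a compound carrying a dimethylamino group, which compound 4 lacks, as does compound 3. Among the compounds with values here, no measured compound carries a ring at this place, so the size of the step remains uncertain. In this assay, no step beyond the scatter is expected, and the estimate corresponds to a 1.3-fold lower number from compound 3 to compound 4 (0.10 log units; within the scatter). For compound 4 the expected value is 22000 nM, with an estimated range from 7000 nM to 65000 nM.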

Compound 4, half-maximal inhibitory concentration: 23100 nM
Compound 4: the middle estimate sits 1.1-fold (0.02 log units) below what was measured, within the range that was stated.
By their numbers in this assay, from the lowest: compound 1; then compound 2; then compounds 4 and 3 (each within the scatter of the next).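

In this assay, the piperidine amide and the diol amide cannot be told apart, at a 1.2-fold lower number from compound 3 to compound 4 (0.08 log units; within the scatter), even though the ring replaces an open chain and the hydrogen-bond donors and acceptors counted on the (2,3-dihydroxypropyl)amino group are absent from 3-methylpiperidin-1-yl. Compound 4 also stands apart from both compounds that carry a dimethylamino group, at a 2.1-fold higher number from compound 2 to compound 4 (0.31 log units; beyond the scatter) and at a 7.5-fold higher number from compound 1 to compound 4 (0.88 log units; beyond the scatter), so among these four compounds the lower numbers go only with the dimethylamino chain, and neither compound without it goes against this. Nothing available explains why the numbers fall this way.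

On these data alone, it remains open whether a piperidine ring bearing a dimethylamino group would bring the number towards that of compound 1, at 3070 nM, which would show whether the ring and the amine can work together on this carbonyl carbon. As far as these compounds go, the contribution of the methyl group in 3-methylpiperidin-1-yl is also open, and a plain piperidin-1-yl or a morpholin-4-yl group would address it.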